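Trimethoxyphenyl in place of methoxyphenyl on the benzyl ether

The source may hold more compounds than are shown below. What is called first, only, known or untested is meant among the compounds shown, and "the series" means these compounds.

This account concerns three measured compounds and a fourth that awaits testing in a functional assay on Mahlavu cells (Homo sapiens) for antiproliferative activity, read by sulforhodamine B assay, with a stated time of 72 h; a higher number here means a weaker inhibitor, a lower number a stronger inhibitor. Compound 1 `FC(F)(F)c1ccc(CN2CCN(Cc3cc(-c4ccc(OCc5ccccc5)cc4)on3)CC2)cc1` gives 11700 nM. Compound 2 `N#Cc1ccccc1COc1ccc(-c2cc(CN3CCN(Cc4ccc(C(F)(F)F)cc4)CC3)no2)cc1` gives 3500 nM, and compound 3 `COc1ccccc1COc1ccc(-c2cc(CN3CCN(Cc4ccc(C(F)(F)F)cc4)CC3)no2)cc1` gives 3900 nM. Compound 3 therefore stands second highest of the three numbers, within the scatter of compound 2 and a longer way from compound 1.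

The step to compound 4 `COc1cc(COc2ccc(-c3cc(CN4CCN(Cc5ccc(C(F)(F)F)cc5)CC4)no3)cc2)cc(OC)c1OC` is 3,4,5-trimethoxyphenyl in place of 2-methoxyphenyl on a saturated chain carbon bound to an oxygen on an aromatic ring. Among the measured compounds shown here, two measured steps bear on it. The first is a 3.0-fold lower number from compound 1 to compound 3 (0.48 log units; beyond the scatter), which shows that a methoxy placed on the benzyl ring moves the number down modestly. The second is a 1.1-fold higher number from compound 2 to compound 3 (0.05 log units; within the scatter), which shows that a methoxy and a cyano at that position give numbers within the scatter of each other. For the measured compounds named here, no measured step shows the effect of more than one methoxy on that ring, so the direction of the step from a single methoxy to three must rest on the gain seen from compound 1 to compound 3 alone.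

On that basis a modest further lowering in this assay is expected for compound 4, and the step of a 1.4-fold lower number from compound 3 to compound 4 (0.14 log units; within the scatter) is the estimate. Compound 4 is expected to give 2800 nM, with a range from 900 nM to 9000 nM.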

Compound 4, half-maximal inhibitory concentration: 5800 nM
Compound 4: middle estimate off by 2.1-fold (0.32 log units), on the low side; low and high end bracket the measured number.
By their numbers in this assay, from the lowest: compounds 2, 3, 4 and 1 (each within the scatter of the next, the first and the last beyond it).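

In this assay, among the compounds shown here, this position accepts 3,4,5-trimethoxyphenyl with no step that leaves the scatter: a 1.5-fold higher number from compound 3 to compound 4 (0.17 log units; within the scatter) and a 1.7-fold higher number from compound 2 to compound 4 (0.22 log units; within the scatter) both stay within it, so the three methoxy groups cannot be told apart here from 2-methoxyphenyl or 2-cyanophenyl. The new information lies in the comparison with the plain phenyl, where a 2.0-fold lower number from compound 1 to compound 4 (0.30 log units; within the scatter) also stays within the scatter, while a 3.0-fold lower number from compound 1 to compound 3 (0.48 log units; beyond the scatter) and a 3.3-fold lower number from compound 1 to compound 2 (0.52 log units; beyond the scatter) lie beyond it, so compound 4 alone among the substituted compounds is not separated from compound 1, and the extra methoxy groups add no measurable lowering to what a single methoxy gave. Nothing on hand accounts for these numbers.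

The compounds shown leave open whether the count of methoxy groups or their placing matters more, as compound 3 and compound 4 differ in both at once. They also leave open how a hydroxyl, an amine or a carboxylic acid on this ring would read in this assay.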